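A Second Chloro Added to a Weak Sigma-2 Ligand

The source may hold more compounds than are shown below. What is called first, only, known or untested is meant among the compounds shown, and "the series" means these compounds.

Compound 1, `Cc1ccc(-c2nc(CN3CCCC3)nn2C)cc1`, gives in an assay on membranes from Jurkat cells for displacement of a labelled ligand from Sigma intracellular receptor 2 (Homo sapiens), read by scintillation counting, with a stated time of 1 h (a higher number here means a weaker inhibitor, a lower number a stronger inhibitor), a value of > 1000 nM, which is a limit of the assay and not a number.
Compound 2, `Cn1nc(CN2CCCC2)nc1-c1ccc(Cl)cc1`, gives in this assay a value of > 1000 nM, again a limit rather than a measured number.

On the numbers shown, compound 2 therefore stands at the limit of this assay, with no number of its own. For the measured compounds named here, the one measured step, a step that the two limits leave unreadable from compound 1 to compound 2, cannot be sized, because the limit of > 1000 nM in this assay, at which 2 of the 2 values shown sit, describes both of its ends. Compound 3, `Cn1nc(CN2CCCC2)nc1-c1ccc(Cl)c(Cl)c1`, differs from compound 2 by chloro in place of hydrogen on an aromatic carbon. No readable measured step bears on this change: the step from compound 1 to compound 2 is the only one available and it tells nothing about size or direction. Going by the values given here, nothing among the measured compounds points to a gain beyond the scatter, so compound 3 is expected to stay near the limit, with an estimated value of 2000 nM and a range from 600 nM to 8000 nM. The step implied by this estimate, a step that the limit leaves unreadable from compound 2 to compound 3, is expected to be small and most likely hidden behind the limit again.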

Compound 3, inhibition constant: > 1000 nM
Compound 3: no number, only a limit (the forecaster's own chance of this, stated with the estimate: 70%); the middle value does not contradict the limit.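

In this assay compound 3 gives > 1000 nM, which is a limit and not a number. The step from compound 2 to compound 3 cannot be read, because both of its ends sit at a limit: the limit of > 1000 nM in this assay, at which 3 of the 3 values shown sit. The compounds shown leave open what number any of the three would have in this assay, and whether the added chloro changes it in either direction.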